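Sulfonamide-nitrogen substituents: 2-chlorobenzyl follows propargyloxymethyl

The compounds below may be only part of what the source reports. "The series", "measured", "known", "first", "only" and "open" are said of these compounds alone.

Compound 1 `O=C1c2ccccc2N(Cc2ccc(Cl)c(Cl)c2)S(=O)(=O)N1Cc1ccccc1` carries a 3,4-dichlorobenzyl group on the sulfonamide nitrogen of the shared core and gives 16400 nM in a functional assay on CCRF-CEM cells (Homo sapiens) for inhibition; a higher number here means that more compound is tolerated, a lower number that less compound is tolerated. Compound 2 `C#CCOCN1c2ccccc2C(=O)N(Cc2ccccc2)S1(=O)=O` carries a (propargyloxy)methyl group at the same place and gives 23000 nM in this assay. The step of a 1.4-fold higher number from compound 1 to compound 2 (0.15 log units; within the scatter) is the only one measured so far, so compound 2 and compound 1 simply lie within the scatter of each other; neither number can be called different from the other.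

Compound 3 `O=C1c2ccccc2N(Cc2ccccc2Cl)S(=O)(=O)N1Cc1ccccc1` has not been measured. It differs from compound 2 by 2-chlorophenyl in place of propargyloxy on a saturated chain carbon bound to a sulfonamide nitrogen in a ring. For the measured compounds named here, the one step that bears on this place, a 1.4-fold higher number from compound 1 to compound 2 (0.15 log units; within the scatter), exchanged an aryl group for the propargyloxy group at the same position without leaving the scatter; compound 3 goes the other way, from propargyloxy back to an aryl group, now 2-chlorophenyl instead of 3,4-dichlorophenyl. No step beyond the scatter is therefore expected in this assay, in either direction. Compound 3 is expected to give about 18000 nM, with a range from 7000 nM to 45000 nM, which means an expected step of a 1.3-fold lower number from compound 2 to compound 3 (0.11 log units; within the scatter).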

Compound 3, half-maximal cytotoxic concentration: 27900 nM
Beside the measured number, compound 3's estimate is 1.6-fold (0.19 log units) below it; low and high end bracket the measured number.
By their numbers in this assay, from the lowest: compounds 1, 2 and 3 (each within the scatter of the next).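

In this assay, putting 2-chlorophenyl in place of propargyloxy on a saturated chain carbon bound to a sulfonamide nitrogen in a ring gives a 1.2-fold higher number from compound 2 to compound 3 (0.08 log units; within the scatter), and putting it in place of 3,4-dichlorophenyl at the same place gives a 1.7-fold higher number from compound 1 to compound 3 (0.23 log units; within the scatter). The position now has a comparison between two chlorinated aryl groups as well as one between an aryl group and propargyloxy, and neither change leaves the scatter, so the three compounds cannot be placed in any order and the series shows no dependence on this substituent so far. No accompanying data bear on these results, and the values offer no explanation of them.

Still open, going by these compounds, is whether a group of a different kind at this place, such as a carboxylic acid or a longer chain ending in an amine, would give a step beyond the scatter. The rest of the shared core is the same in all three compounds, so nothing can yet be read about any other place in the series.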